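The source may report more compounds than this note shows. Statements on the series, on what has been measured and on what is new or still open speak of the compounds shown alone.

Measured in a functional assay on BaF3 cells (Mus musculus) for inhibition, read by CCK-8 assay, with a stated time of 72 h (a lower number here means a stronger inhibitor of growth, a higher number a weaker inhibitor of growth), so far:
- compound 1 `CC(=O)Nc1cc(Oc2ccc(NC(=O)Nc3ccc(CN4CCN(C)CC4)c(C(F)(F)F)c3)cc2)ncn1` gives 50 nM
- compound 2 `CC(=O)Nc1cc(Oc2ccc(NC(=O)Nc3ccc(C)c(C(F)(F)F)c3)cc2)ncn1` gives 3230 nM
- compound 3 `Cc1ccc(NC(=O)Nc2ccc(Oc3cc(N4CCNC[C@H]4C)ncn3)cc2)cc1C(F)(F)F` gives 9670 nM

Compound 3 has the highest number of the three. The next change, to compound 4 `Cc1ccc(NC(=O)Nc2ccc(Oc3cc(NCCN)ncn3)cc2)cc1C(F)(F)F`, puts (2-aminoethyl)amino in place of 2-methylpiperazin-1-yl on an aromatic carbon in all. Going by the values given here, the one measured change on this aromatic carbon, a 3.0-fold higher number from compound 2 to compound 3 (0.48 log units; beyond the scatter) with 2-methylpiperazin-1-yl entering, was modest. The large 65-fold higher number from compound 1 to compound 2 (1.81 log units; beyond the scatter) comes from a change elsewhere in the molecule and bears on this one only weakly. No step beyond the scatter is therefore expected in this assay, with a lower number slightly more likely if anything. The estimate means a 1.6-fold lower number from compound 3 to compound 4 (0.21 log units; within the scatter) as the expected step. Compound 4 is estimated at 6000 nM with an expected range from 2000 nM to 15000 nM in this assay series.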

Compound 4, concentration for 50% growth inhibition: > 10000 nM
Compound 4: only a limit was reported (the forecaster's own chance of this, stated with the estimate: 15%); middle value at least 1.6-fold (0.22 log units) from the limit.
By their numbers in this assay, from the lowest: compound 1; then compound 2; then compound 3. At a limit, above all of these: compound 4.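

In this assay compound 4 gives > 10000 nM, which is a limit and not a number. With an at least 3.0-fold higher number from compound 2 to compound 4 (0.49 log units; beyond the scatter), acetamido at this aromatic carbon now stands ahead of a second amine-bearing group, open-chain this time, as it did ahead of 2-methylpiperazin-1-yl. With an at least 1.0-fold higher number from compound 3 to compound 4 (0.01 log units; that floor lies within the scatter), the floor lies within the scatter, so the ring and the open chain cannot be ordered because of the assay ceiling: the limit of > 10000 nM in this assay, at which 1 of the 4 values shown sits.

Still open, going by these compounds, is how a longer diamine chain or a morpholine ring would fare at this carbon. Also open, on these data alone, is whether either amine group would fare differently alongside the 4-methylpiperazin-1-yl side chain of compound 1.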